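A few compounds are considered here, and "the series" means these few. Any claim that something is new, unique, unknown or untested is made for them only; others in the source may bear on it.

Measured so far in a functional assay on NCI-H661 cells (Homo sapiens) for antiproliferative activity, read by MTT assay, with a stated time of 72 h (on this read-out higher numbers stand for weaker inhibition and lower numbers for stronger inhibition), are three compounds

Compound 1 `Nc1ccccc1NC(=O)CCCCCCc1nc(-c2ccc([N+](=O)[O-])cc2)no1` gives > 100000 nM as a limit of the assay, not a number
Compound 2 `COc1ccc(-c2noc(CCCCCCC(=O)C(F)(F)F)n2)cc1` gives 5050 nM
Compound 3 `O=C(CCCCCCc1nc(-c2ccc(C(F)(F)F)cc2)no1)C(F)(F)F` gives 6390 nM

Among the measured compounds shown here, of the two true numbers, the one for compound 3 at 6390 nM lies within the usual scatter of the one for compound 2 at 5050 nM and so the two cannot be ranked. Compound 4 `O=C(CCCCCCc1nc(-c2ccc([N+](=O)[O-])cc2)no1)C(F)(F)F` has not yet been measured. It is compound 3 with nitro in place of trifluoromethyl on an aromatic carbon, para to a large group (nitro in place of trifluoromethyl on an aromatic carbon). For the measured compounds named here, one measured step bears on this, also a swap on an aromatic carbon, with trifluoromethyl in place of methoxy: a 1.3-fold higher number from compound 2 to compound 3 (0.10 log units; within the scatter). Compound 1 also carries nitro but differs from compound 4 elsewhere, so it offers no clean comparison. Going by that single small step, no change beyond the scatter is expected in this assay and the expected step is a 1.1-fold lower number from compound 3 to compound 4 (0.03 log units; within the scatter) in this estimate. With so little evidence the range is kept wide. Compound 4 is estimated at 6000 nM with an expected range of 2500 nM to 15000 nM in this assay's terms.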

Compound 4, half-maximal inhibitory concentration: 17500 nM
Estimate against measurement, compound 4: 2.9-fold (0.46 log units) below; the measured number lies above the stated range.
By their numbers in this assay, from the lowest: compounds 2 and 3 (each within the scatter of the next); then compound 4. At a limit, above all of these: compound 1.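

In this assay, the group on this aromatic carbon, para to a large group, can matter: nitro in place of trifluoromethyl gives a 2.7-fold higher number from compound 3 to compound 4 (0.44 log units; beyond the scatter), and nitro in place of methoxy gives a 3.5-fold higher number from compound 2 to compound 4 (0.54 log units; beyond the scatter), although the swap of methoxy for trifluoromethyl gave a 1.3-fold higher number from compound 2 to compound 3 (0.10 log units; within the scatter). Among these three groups, nitro alone stands apart, with weaker inhibition. Both compounds with nitro can still be told apart by the group on the carbonyl carbon, where trifluoromethyl in place of (2-aminophenyl)amino gives an at least 5.7-fold lower number from compound 1 to compound 4 (0.75 log units; beyond the scatter), a step that rests on a limit for compound 1 and not on a number: the limit of > 100000 nM in this assay, at which 1 of the 4 values shown sits.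

From the compounds shown here alone, what sets nitro apart from methoxy and trifluoromethyl remains open. An amine or a carboxylic acid on the same aromatic carbon could show whether this weaker inhibition is particular to nitro, while a longer chain could show whether the step holds on a different linker.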